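This account rests on a few compounds, and the source may have more. Where it says the series, first, only, none or still open, it means among the compounds named here.

Of the compounds shown here, three have been measured in an ADME assay on S9 fraction from liver (Rattus norvegicus) for metabolic stability, read by LC-MS, using NADPH, with a stated time of 30 min; on this read-out lower numbers stand for a less stable compound and higher numbers for a more stable compound. Compound 1 `CCCCCCCCc1ccc(OCC(=O)Cn2nnc(-c3ccccc3)n2)cc1` gives 33% in this assay. Compound 2 `CCCCCCCCc1ccc(OCC(=O)Cn2nnnc2C(=O)OC)cc1` and compound 3 `CCCCCCCCc1ccc(OCC(=O)Cn2nnnc2C(=O)OCC)cc1` rest on a different core from compound 1; how the two cores differ is not broken down here. In this assay compound 2 gives 38%, and compound 3 gives 33%. For the measured compounds named here, the single change between them, (methyl in place of hydrogen on a saturated chain carbon bound to an oxygen next to a carbonyl group), made a number 5 percentage points lower from compound 2 to compound 3 (within the scatter). Compound 1 stands level with compound 3 at the digits given, and both other compounds lie within the scatter of it.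

Compound 4 `CCCCCCCCc1ccc(OC(C)C(=O)Cn2nnc(-c3ccccc3)n2)cc1` has not yet been measured. It differs from compound 1 by methyl in place of hydrogen on a saturated chain carbon bound to a carbonyl carbon and an oxygen on an aromatic ring. Going by the values given here, this is the same kind of change as the one from compound 2 to compound 3, though the place is not the same: there the saturated chain carbon is bound to an oxygen next to a carbonyl group, here to a carbonyl carbon and an oxygen on an aromatic ring. The expectation rests on the step of a number 5 percentage points lower from compound 2 to compound 3 (within the scatter), which stayed within the scatter. For compound 4 a step of about a number 2 percentage points lower from compound 1 to compound 4 (within the scatter) is expected in this assay. Compound 4 is therefore estimated to give 31% in this assay, with a range from 16% to 46%.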

Compound 4, percent of the compound remaining: 40%
Compound 4: middle estimate off by 9 percentage points, on the low side; the measured number falls inside the stated range.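

Putting methyl in place of hydrogen on a saturated chain carbon bound to a carbonyl carbon and an oxygen on an aromatic ring gave a number 7 percentage points higher from compound 1 to compound 4 (within the scatter) in this assay. Set beside the earlier step on the other core, the two steps do not differ beyond what repeated measurements would allow: the same change on two cores in this assay, a number 5 percentage points lower (within the scatter) from compound 2 to compound 3 and a number 7 percentage points higher (within the scatter) from compound 1 to compound 4, 12 percentage points apart, within the scatter of two such steps. This shows no difference between the two cores for this change in this assay, but it does not show that the methyl has an effect of its own on either core, or that a step on one core can predict a step on another, and the two methyl groups do not stand at the same place.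

The compounds shown leave open how an ethyl group, a longer chain or a fluorine atom on the same saturated chain carbon would read in this assay. They also leave open whether the methyl change would give a step beyond the scatter on any further core.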